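The source may hold more compounds than are shown below. What is called first, only, known or untested is meant among the compounds shown, and "the series" means these compounds.

For the measured compounds named here, compound 2 `CCOC(=O)C1=CCCCC1S(=O)(=O)Cc1ccc(Cl)cc1` is one of two measured members of a small set sharing the same core, and in a functional assay on RAW264.7 cells (Mus musculus), read by fluorescence (a lower number here means a stronger inhibitor, a higher number a weaker inhibitor), compound 2 gives 101 nM, the only number recorded for it, with a further entry that yielded no single number. Compound 1 `CCOC(=O)C1=CCCCC1S(=O)(=O)Cc1ccc(F)cc1Cl` carries a fluoro group with a chloro group on the same ring; in this assay compound 1 gives 10 nM; 10000 nM; 5.7 nM (3 entries), and the three entries disagree widely (the several entries of compound 1 in this assay, 10 nM; 10000 nM; 5.7 nM (3 entries)), two of them close together and one far weaker. The next compound, compound 3 `CCOC(=O)C1=CCCCC1S(=O)(=O)Cc1ccc(Cl)cc1Cl`, differs from compound 2 by one change: chloro in place of hydrogen on an aromatic carbon. Going by the values given here, no measured pair shows this same change, so the size of the step is open. Compound 3 is expected to be a stronger inhibitor than compound 2, with an estimated step of a 6.7-fold lower number from compound 2 to compound 3 (0.83 log units; beyond the scatter), since compound 1, which also carries the added chloro group, gives 10 nM; 10000 nM; 5.7 nM (3 entries) in most entries. Compound 3 is therefore estimated at 15 nM, within a range from 3 nM to 150 nM.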

Compound 3, half-maximal inhibitory concentration: 60 nM
For compound 3 the middle estimate is 4.0-fold (0.60 log units) below the measured one; the measured number falls inside the stated range.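

In this assay, the change of hydrogen to chloro on this aromatic carbon, ortho to a large group and meta to a chloro group, now has a measured size: a 1.7-fold lower number from compound 2 to compound 3 (0.23 log units; within the scatter). On this one pair, then, the added chloro group does not separate compound 3 from compound 2. Compound 1 carries a chloro group at the same place and differs from compound 3 in having a fluoro group where compound 3 has its other chloro group, but it offers no single number to set against compound 3: the several entries of compound 1 in this assay, 10 nM; 10000 nM; 5.7 nM (3 entries).

The compounds shown leave open whether a methyl or a methoxy group on this same carbon would give a step beyond the scatter. They also leave open whether the chloro step would stay this size with a carboxylic acid in place of the ethyl ester.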